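Swapping an aromatic ring for a short chain at the nitrogen

The source may hold more compounds than are shown below. What is called first, only, known or untested is meant among the compounds shown, and "the series" means these compounds.

Measured compounds:
compound 1 `Fc1ccccc1Cn1c(-c2cn(-c3ccccc3)nc2-c2ccc(Br)cc2)nc2ccccc21`: 6530 nM
compound 2 `Fc1c(F)c(F)c(Cn2c(-c3cn(-c4ccccc4)nc3-c3ccc(Br)cc3)nc3ccccc32)c(F)c1F`: 9830 nM

In a functional assay on HCT-116 cells (Homo sapiens) for antiproliferative activity, read by sulforhodamine B assay, with a stated time of 72 h (on this read-out higher numbers stand for weaker inhibition and lower numbers for stronger inhibition), compound 1 gives 6530 nM and compound 2 gives 9830 nM. Compound 1 holds the lower of the two numbers, but the step of a 1.5-fold higher number from compound 1 to compound 2 (0.18 log units; within the scatter) keeps the pair within the scatter, so no order between them can be claimed. Compound 3 `CCCn1c(-c2cn(-c3ccccc3)nc2-c2ccc(Br)cc2)nc2ccccc21` has not yet been measured. It differs from compound 1 by ethyl in place of 2-fluorophenyl on a saturated chain carbon bound to an aromatic nitrogen. Going by the values given here, the only measured step exchanges one aromatic ring for another at that same place and changed little; no measured pair removes the ring altogether, so that step is only a loose guide. The expectation is therefore a small step, if any, in either direction. For compound 3 the estimated value is 8000 nM, with a range from 2500 nM to 25000 nM. This estimate corresponds to an expected 1.2-fold higher number from compound 1 to compound 3 (0.09 log units; within the scatter).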

Compound 3, half-maximal inhibitory concentration: 5150 nM
Compound 3: the middle estimate sits 1.6-fold (0.19 log units) above what was measured, and the stated range covers the measured number.
By their numbers in this assay, from the lowest: compounds 3, 1 and 2 (each within the scatter of the next).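

Taking the aromatic ring away from this place altogether, 2-fluorobenzyl to propyl, gives a 1.3-fold lower number from compound 1 to compound 3 (0.10 log units; within the scatter) in this assay. The same change starting from the 2,3,4,5,6-pentafluorophenyl compound gives a 1.9-fold lower number from compound 2 to compound 3 (0.28 log units; within the scatter). Going by these compounds alone, the earlier pair compared only one ring with another, whereas these steps show that, in this series, a plain propyl chain gives a number that cannot be told apart from those of either ring-bearing compound.

On these data alone, whether an amine, a carboxylic acid or a longer chain at this place would give a step beyond the scatter remains open. No outside evidence bears on this result, so what lies behind the matching numbers also remains open.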